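Compound 3: 1,3-oxazol-4-yl in place of 1H-pyrazol-4-yl

A few compounds are considered here, and "the series" means these few. Any claim that something is new, unique, unknown or untested is made for them only; others in the source may bear on it.

Values in an ADME assay on microsomes (Rattus norvegicus) for metabolic stability; a lower number here means that the compound disappears faster, a higher number that the compound lasts longer:
- compound 1 `O=C(C1CCN(C(=O)C(F)(F)F)CC1)N1N=CCC1c1ccccc1`: 0.483 h
- compound 2 `O=C(c1cn[nH]c1)N1CCC(C(=O)N2N=CCC2c2ccccc2)CC1`: > 2.75 h
- compound 3 `O=C(c1cocn1)N1CCC(C(=O)N2N=CCC2c2ccccc2)CC1`: not yet measured

For compound 2, > 2.75 h is a limit of the assay and not a number. The change under study is 1,3-oxazol-4-yl in place of 1H-pyrazol-4-yl on a carbonyl carbon, with 1,3-oxazol-4-yl in place of 1H-pyrazol-4-yl on a carbonyl carbon. Going by the values given here, the one measured step, an at least 5.6-fold higher number from compound 1 to compound 2 (0.75 log units; beyond the scatter), removed trifluoromethyl, so it gives no direct size for this exchange. No change beyond the scatter is expected in this assay, and the estimated step is an at least 1.1-fold lower number from compound 2 to compound 3 (0.04 log units; that floor lies within the scatter). Compound 3 is expected at 2.5 h, with an estimated range of 1.1 h to 5.5 h.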

Compound 3, half-life: 0.533 h
The estimate for compound 3 lay 4.7-fold (0.67 log units) above the measured number, outside the stated range (below it).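

In this assay, the two five-membered aromatic rings on this carbonyl carbon are not interchangeable: the exchange gives an at least 5.1-fold lower number from compound 2 to compound 3 (0.71 log units; beyond the scatter). The figure for compound 2 is a limit and not a number, so this step is only a floor: the limit of > 2.75 h in this assay, at which 1 of the 3 values shown sits. Trifluoromethyl and 1,3-oxazol-4-yl on the same carbon are not separated, with a 1.1-fold higher number from compound 1 to compound 3 (0.04 log units; within the scatter).

The compounds shown do not separate the loss of the hydrogen-bond donor in 1H-pyrazol-4-yl from the other differences between the two rings. Also open, from the compounds shown here alone, is how an imidazole ring on this carbonyl carbon would read in this assay.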